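Methoxy in place of trifluoromethyl on the shared core

The source may hold more compounds than are shown below. What is called first, only, known or untested is meant among the compounds shown, and "the series" means these compounds.

Compound 3 `C/C(=C\c1cc(-c2ccc(C(F)(F)F)cc2)cs1)C(N)=O` stands at the higher of the two numbers given in a functional assay on MCF7 cells (Homo sapiens) for cytotoxicity, read by CCK-8 assay, with a stated time of 24 h (a higher number here means a weaker inhibitor, a lower number a stronger inhibitor), where compound 3 gives 50000 nM. Compound 2 `C/C(=C\c1cc(-c2ccc([N+](=O)[O-])cc2)cs1)C(N)=O` gives 1210 nM in the same assay, and the step is a 41-fold higher number from compound 2 to compound 3 (1.62 log units; beyond the scatter). Compound 1 `C/C(=C\c1cc(-c2ccc(S(C)(=O)=O)cc2)cs1)C(N)=O` reaches only the limit of this assay, > 50000 nM, which is a limit and not a number (the limit of > 50000 nM in this assay, at which 1 of the 3 values shown sits); the step from it is a number no higher from compound 1 to compound 3 (the limit leaves the size open). Compound 4 `COc1ccc(-c2csc(/C=C(\C)C(N)=O)c2)cc1` differs from compound 3 in one place: methoxy in place of trifluoromethyl on an aromatic carbon. Among the compounds with values here, no measured step involves a methoxy group, so the two steps that touch compound 3 bear only indirectly: they show that exchanging one para group for another can move the number a great deal, as a 41-fold higher number from compound 2 to compound 3 (1.62 log units; beyond the scatter), or leave it at the limit. Within the data shown here, with no direct precedent, the estimate for compound 4 is an expected step of a 2.5-fold lower number from compound 3 to compound 4 (0.40 log units; beyond the scatter). Compound 4 is therefore expected at 20000 nM, with a range from 3000 nM to 50000 nM.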

Compound 4, half-maximal inhibitory concentration: > 50000 nM
Compound 4: a limit, no number; the forecaster's own chance of this, stated with the estimate: 40%; middle value at least 2.5-fold (0.39 log units) from the limit.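

In this assay compound 4 gives > 50000 nM, which is a limit and not a number, so methoxy joins methylsulfonyl at the top of the range: the limit of > 50000 nM in this assay, at which 2 of the 4 values shown sit.

Exchanging trifluoromethyl for methoxy brought no gain at this position, with a number no lower from compound 3 to compound 4 (the limit leaves the size open), while the change from nitro shows an at least 41-fold higher number from compound 2 to compound 4 (1.61 log units; beyond the scatter). Nitro thus remains the only one of the four groups whose value lies well clear of the limit, and the step between the two compounds at the limit, compound 1 and compound 4, cannot be read.

From the compounds shown here alone, how far compound 1 and compound 4 lie past the limit stays open. The compounds shown also leave open whether nitro is alone in this, since an amine or a carboxylic acid at this position could give a value either way.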